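Replacing fluoro with methoxy in compound 1

This account rests on a few compounds, and the source may have more. Where it says the series, first, only, none or still open, it means among the compounds named here.

Among the compounds with values here, in a functional assay on HeLa cells (Homo sapiens) for antiproliferative activity, read by MTT assay, with a stated time of 48 h (a lower number here means a stronger inhibitor, a higher number a weaker inhibitor), compound 1 `Fc1ccc(-c2nn(-c3ccccc3)cc2-c2nc3cc(Cl)ccc3[nH]2)cc1` gives 2770 nM, the lowest number measured so far, though compound 2 `Cc1ccc2[nH]c(-c3cn(-c4ccccc4)nc3-c3ccc(F)cc3)nc2c1`, at 3630 nM, cannot be told apart from it. Methyl in place of chloro gives a 1.3-fold higher number from compound 1 to compound 2 (0.12 log units; within the scatter). Compound 3 `O=C(OCc1ccccc1)c1ccc2[nH]c(-c3cn(-c4ccccc4)nc3-c3ccc(F)cc3)nc2c1` gives 23600 nM, and benzyloxycarbonyl in place of chloro gives an 8.5-fold higher number from compound 1 to compound 3 (0.93 log units; beyond the scatter).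

Compound 4 `COc1ccc(-c2nn(-c3ccccc3)cc2-c2nc3cc(Cl)ccc3[nH]2)cc1` instead has methoxy in place of fluoro, turning 4-fluorophenyl into 4-methoxyphenyl: methoxy in place of fluoro on an aromatic carbon. Within the data shown here, all the measured steps change another aromatic carbon, so none tests this swap directly, and no shift beyond the scatter can be predicted with any confidence. The expected result is a 1.1-fold higher number from compound 1 to compound 4 (0.03 log units; within the scatter). For compound 4 the estimated value is 3000 nM, within an expected range of 1100 nM to 9000 nM.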

Compound 4, half-maximal inhibitory concentration: 1290 nM
Compound 4: the middle estimate sits 2.3-fold (0.37 log units) above what was measured, and the stated range covers the measured number.
By their numbers in this assay, from the lowest: compound 4; then compounds 1 and 2 (each within the scatter of the next); then compound 3.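

Within the data shown here, all the earlier steps changed another aromatic carbon. Here the change is on the phenyl ring itself: turning 4-fluorophenyl into 4-methoxyphenyl gives a 2.1-fold lower number from compound 1 to compound 4 (0.33 log units; beyond the scatter) in this assay. This place therefore responds to substitution, and the larger methoxy group is accepted with a modest step toward a lower number. Nothing measured here accounts for the shift.

A single swap leaves open whether a hydroxy group, an ethoxy group or a dimethylamino group at this place would do the same. It also leaves open whether methoxy would have a similar effect with the methyl group of compound 2 or the benzyloxycarbonyl group of compound 3 in place of chloro.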